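A few compounds are considered here, and "the series" means these few. Any claim that something is new, unique, unknown or untested is made for them only; others in the source may bear on it.

Working notes on the series.

Compound 1 `Cc1cc(O)c(C(C)C)cc1-c1cc(-c2cccs2)c(C#N)c(=O)[nH]1` gives 68% in a functional assay for inhibition, tested at 100 ug/mL; a lower number here means a weaker effect, a higher number a stronger effect of the compound at the concentration tested. Compound 2 `Cc1cc(O)c(C(C)C)cc1-c1cc(-c2ccc(N(C)C)cc2)c(C#N)c(=O)[nH]1` gives 68% in this assay, and the step of no change at the digits printed from compound 1 to compound 2 (within the scatter) shows that the swap on that aromatic carbon left the read-out where it was. Compound 2 therefore stands level with compound 1 on the numbers in hand; with two compounds at the same reading there is no spread in the series yet, and neither can be called the stronger.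

Compound 3 `Cc1cc(O)c(C(C)C)cc1-c1cc(-c2ccccc2Cl)c(C#N)c(=O)[nH]1` is the next member. The difference from compound 2 is 2-chlorophenyl in place of 4-(dimethylamino)phenyl on an aromatic carbon. Within the data shown here, the only measured step that bears on this kind of exchange is the one from compound 1 to compound 2, which was within the scatter, so a second exchange at the same place is expected to fall within the scatter as well; the data give no direction. The step of no change at the digits printed from compound 2 to compound 3 (within the scatter) is the expected outcome. Compound 3 is thus estimated at 68% in this assay, with a range from 50% to 82%.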

Compound 3, a percentage reported as inhibition, at one concentration (the size of the read-out at that concentration, not a potency): 34%
The estimate for compound 3 lay 34 percentage points above the measured number; measured number below the stated range.
By their numbers in this assay, from the lowest: compound 3; then compounds 1 and 2 (each within the scatter of the next).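

The place opposite the ring nitrogen, ortho to a cyano group, does respond to the group it carries: with 2-chlorophenyl in place of 4-(dimethylamino)phenyl, this assay shows a number 34 percentage points lower from compound 2 to compound 3 (beyond the scatter), and with 2-chlorophenyl in place of thiophen-2-yl it shows a number 34 percentage points lower from compound 1 to compound 3 (beyond the scatter). The level reading of compound 1 and compound 2 therefore does not mean that exchanges at this place are generally without effect, and compound 3 is the weakest of the three at the concentration tested. No measurement bearing on the origin of this drop is available, so the three numbers give the size of the change but not its reason.

On these data alone, it remains open whether the drop belongs to the chlorine itself or to the 2-chlorophenyl group as a whole, since the three groups differ from one another in more than one respect. A plain phenyl group would separate these readings, as would a methoxy group standing in place of the chlorine, and either would show how much of the read-out depends on that substituent.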